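Amide and aryl variation in a small cytotoxicity series

A few compounds are considered here, and "the series" means these few. Any claim that something is new, unique, unknown or untested is made for them only; others in the source may bear on it.

Values below are from a functional assay on QGY7701 cells (Homo sapiens) for cytotoxicity, read by MTT assay, with a stated time of 24 h; a higher number here means a weaker inhibitor, a lower number a stronger inhibitor.

Compound 1 `C=CC1=C(C(=O)NC2CCCCC2)C(c2ccc(OC)cc2)OC1`: > 100000 nM
Compound 2 `C=CC1=C(C(=O)NCCCCC)C(c2ccc(F)cc2)OC1`: > 100000 nM
Compound 3 `C=CC1=C(C(=O)NCCCCC)C(c2ccc(OC)cc2)OC1`: > 100000 nM

Each of these three values is a limit of the assay and not a number. The step that the two limits leave unreadable from compound 3 to compound 1 belongs to the change (cyclohexyl in place of pentyl on an amide-type nitrogen). The step that the two limits leave unreadable from compound 2 to compound 3 rests on the difference between the two cores, (fluoro in place of methoxy on an aromatic carbon). Neither step has a readable size, as all three values sit at the limit of > 100000 nM in this assay, at which 3 of the 3 values shown sit.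

Compound 4 `C=CC1=C(C(=O)NC2CCCCC2)C(c2ccc(F)cc2)OC1` has not yet been measured. It differs from compound 2 by cyclohexyl in place of pentyl on an amide-type nitrogen. The place line is the same word for word as for the pair from compound 3 to compound 1, so this is the same change, carried out on the core of compound 2 rather than that of compound 3. The earlier step gave no readable size, and compound 2 itself sits at the limit, so nothing measured points to a number below it. On that footing the expected step in this assay is a step that the limit leaves unreadable from compound 2 to compound 4. The estimate for compound 4 is 150000 nM, with a range from 80000 nM to 500000 nM, most likely reported again as a limit.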

Compound 4, half-maximal inhibitory concentration: 40500 nM
Estimate against measurement, compound 4: 3.7-fold (0.57 log units) above, and the stated range ends above it.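

In this assay, cyclohexyl in place of pentyl on an amide-type nitrogen gives an at least 2.4-fold lower number from compound 2 to compound 4 (0.39 log units; beyond the scatter), and fluoro in place of methoxy on an aromatic carbon gives an at least 2.4-fold lower number from compound 1 to compound 4 (0.39 log units; beyond the scatter). The same amide change on the core of compound 3, the step from compound 3 to compound 1, cannot be read, and neither can the step from compound 2 to compound 3, since both ends of each sit at the same limit: the limit of > 100000 nM in this assay, at which 3 of the 4 values shown sit. The size of the change on the core of compound 2 is therefore only bounded, and the data neither show nor exclude that it carries over to the core of compound 3.

On these data alone, it remains open whether the drop seen for compound 4 follows from the ring itself or from the cyclohexyl group alone, which a cyclopentyl group or a longer chain on that nitrogen would help to separate. As far as these compounds go, it is also open how the fluoro core would respond to an amine or a carboxylic acid on the aromatic ring.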